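The compounds below may be only part of what the source reports. "The series", "measured", "known", "first", "only" and "open" are said of these compounds alone.

Of the compounds shown here, three built on one shared core have been measured in a functional assay on MGC-803 cells (Homo sapiens) for antiproliferative activity, read by CCK-8 assay, with a stated time of 72 h, tested at 8 uM; a higher number here means a stronger effect of the compound at the concentration tested, a lower number a weaker effect. Compound 1 `Nc1ccccc1NC(=O)c1ccc(CSC(=S)N2CCc3cc([N+](=O)[O-])ccc32)cc1` gives 33.2% in this assay. Compound 2 `COc1ccc(N2CCN(C(=S)SCc3ccc(C(=O)Nc4ccccc4N)cc3)CC2)cc1` gives 22.9%, and compound 3 `Nc1ccccc1NC(=O)c1ccc(CSC(=S)N2CCN(c3ccncc3)CC2)cc1` gives 87.1%. Among these three numbers compound 1 stands second highest: its nearest neighbour is compound 2, whose value lies lower by a margin beyond the scatter, and the furthest is compound 3, whose value lies higher, also beyond the scatter. Going by the values given here, the only step between measured compounds that differ in one place is a number 64.2 percentage points higher from compound 2 to compound 3 (beyond the scatter), brought about by pyridin-4-yl in place of 4-methoxyphenyl on an amine nitrogen in a ring.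

Compound 4 `Nc1ccccc1NC(=O)c1ccc(CSC(=S)N2CCc3cc(Cl)ccc32)cc1` has not yet been measured. It differs from compound 1 as follows: chloro in place of nitro on an aromatic carbon. Among the compounds with values here, this exchange sits on the fused ring of the core, and no measured step touches that part of the molecule; the step from compound 2 to compound 3 concerns another region and does not bear on chloro in place of nitro. With nothing to support a large shift, the step in this assay is expected to be small, a number 3.2 percentage points lower from compound 1 to compound 4 (within the scatter), and within the scatter. Compound 4 is therefore estimated to give 30% in this assay, within a range from 15% to 50%.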

Compound 4, a percentage reported as inhibition, at one concentration (the size of the read-out at that concentration, not a potency): 82.2%
Compound 4: middle estimate off by 52.2 percentage points, on the low side; measured number above the stated range.
By their numbers in this assay, from the lowest: compound 2; then compound 1; then compounds 4 and 3 (each within the scatter of the next).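

Going by these compounds alone, the exchange of nitro for chloro is the first step seen at this position, on an aromatic carbon of the six-membered aromatic ring of carbon only that is part of the fused system, and in this assay it gives a number 49 percentage points higher from compound 1 to compound 4 (beyond the scatter). The earlier compounds shown here showed a large step only at the other end of the molecule, a number 64.2 percentage points higher from compound 2 to compound 3 (beyond the scatter), so this result adds a second place where one exchange moves the read-out well beyond the scatter. The exchange replaces a group of 3 heavy atoms with 2 hydrogen-bond acceptors by a single chlorine atom with 0 hydrogen-bond acceptors, but no measurement at hand ties either difference to the step, and the reason for it remains unexplained.

With only nitro and chloro shown at this position, the compounds leave open whether the higher read-out is particular to chloro or would also be found with fluoro, bromo, methyl, methoxy or an amine there. They also leave open how the read-out depends on the concentration, since each compound is shown at a single one.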